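The compounds below may be only part of what the source reports. "The series", "measured", "known", "first", "only" and "open" are said of these compounds alone.

In a functional assay on A2780 cells (Homo sapiens) for antiproliferative activity, read by sulforhodamine B assay, with a stated time of 48 h (on this read-out higher numbers stand for weaker inhibition of growth and lower numbers for stronger inhibition of growth), compound 1 (`CC(C)(C)[Si](C)(C)O[C@@H]1CCCO[C@@H]1/C=C/C(=O)OCc1ccccc1`) gives 32000 nM. Compound 2 (`O=C(/C=C/[C@H]1OCCC[C@H]1O)OCc1ccccc1`) stands at > 100000 nM, which is a limit of the assay and not a number. Compound 3 (`COC(=O)/C=C/[C@H]1OCCC[C@H]1O`) has hydrogen in place of phenyl on a saturated chain carbon bound to an oxygen next to a carbonyl group. Among the measured compounds shown here, the only measured step, an at least 3.1-fold higher number from compound 1 to compound 2 (0.49 log units; beyond the scatter), lies elsewhere in the molecule and ends at that limit, as the limit of > 100000 nM in this assay, at which 1 of the 2 values shown sits, shows. No step beyond the scatter is therefore expected, since compound 2 already shows > 100000 nM. The expected step is a number no higher from compound 2 to compound 3 (the limit leaves the size open). Compound 3 is expected near 100000 nM, with an estimated range of 50000 nM to 200000 nM.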

Compound 3, concentration for 50% growth inhibition: > 100000 nM
Compound 3: no number, only a limit; the forecaster's own chance of this, stated with the estimate: 80%; the middle value lies on the limit itself.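

No step can be read from compound 2 to compound 3, because both stand at a limit of this assay and not at a number: the limit of > 100000 nM in this assay, at which 2 of the 3 values shown sit.

The compounds shown leave open whether hydrogen in place of phenyl on a saturated chain carbon bound to an oxygen next to a carbonyl group changes growth inhibition at all.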